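Exchanging 2-hydroxyethyl for 1-phenylethyl on the shared core

The source may report more compounds than this note shows. Statements on the series, on what has been measured and on what is new or still open speak of the compounds shown alone.

In a functional assay on HCT-116 cells (Homo sapiens) for cytotoxicity, read by MTT assay, with a stated time of 72 h (on this read-out higher numbers stand for weaker inhibition and lower numbers for stronger inhibition), compound 3 (`O=C(NCc1ccc(F)cc1)c1nc(Br)c2cccnc2c1NCCO`) gives > 20000 nM, which is a limit and not a number. Compound 1 (`C[C@@H](Nc1c(C(=O)NCc2ccc(F)cc2)nc(Br)c2cccnc12)c1ccccc1`) gives > 20000 nM, also a limit. Compound 3 therefore stands with compound 1 at the limit of > 20000 nM in this assay, at which 2 of the 3 values shown sit. Only compound 2 (`N[C@H]1CC[C@H](Nc2c(C(=O)NCc3ccc(F)cc3)nc(Br)c3cccnc23)CC1`) gives a number, 7000 nM.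

Compound 4 (`C[C@H](Nc1c(C(=O)NCc2ccc(F)cc2)nc(Br)c2cccnc12)c1ccccc1`) carries 1-phenylethyl in place of 2-hydroxyethyl on a nitrogen on an aromatic ring. Compound 1 carries the same group, with its defined stereocentre drawn the opposite way in compound 4.

The closest measured change is a step that the two limits leave unreadable from compound 1 to compound 3, the same exchange of groups in reverse, and it gives no size. The other two, an at least 2.8-fold lower number from compound 1 to compound 2 (0.45 log units; beyond the scatter) and an at least 2.8-fold higher number from compound 2 to compound 3 (0.45 log units; beyond the scatter), both turn on 4-aminocyclohexyl, which compound 4 lacks. Neither 2-hydroxyethyl nor 1-phenylethyl has yet given a number in this assay.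

Compound 1 gives > 20000 nM, so compound 4 is expected to stay close to that limit, and no step beyond the scatter is expected in either direction. The expected change is a number no higher from compound 3 to compound 4 (the limit leaves the size open). For compound 4 the estimate is 20000 nM, with an expected range of 9000 nM to 40000 nM.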

Compound 4, half-maximal inhibitory concentration: > 20000 nM
Compound 4: only a limit was reported; the forecaster's own chance of this, stated with the estimate: 70%; the middle value sits exactly at the limit.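

Within the data shown here, replacing 4-aminocyclohexyl with 1-phenylethyl on a nitrogen on an aromatic ring gives an at least 2.8-fold higher number from compound 2 to compound 4 (0.45 log units; beyond the scatter), so compound 2 remains the only compound in this set with a number. In this assay, among these compounds, compound 4 gives > 20000 nM, a limit and not a number, so neither drawn configuration of 1-phenylethyl gives a number at this position, and the pair of compound 1 and compound 4 isolates the stereocentre as the only change: the fact that compounds 1 and 4 differ only in the configuration as drawn. The steps from compound 3 to compound 4 and from compound 1 to compound 4 cannot be read, since both ends of each step are limits: the limit of > 20000 nM in this assay, at which 3 of the 4 values shown sit.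

On these data alone, how far compound 1, compound 3 and compound 4 lie past the limit remains open, and with it any order among 2-hydroxyethyl and the two configurations of 1-phenylethyl. Also open, as far as these compounds go, is whether the step to compound 2 follows the amine or the cyclohexyl ring of 4-aminocyclohexyl, a question that plain cyclohexyl or a straight chain ending in an amine, such as 3-aminopropyl, would address on the shared core.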